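Nitro in Place of Hydrogen: Compound 1 to Compound 4

The compounds below may be only part of what the source reports. "The series", "measured", "known", "first", "only" and "open" are said of these compounds alone.

Compound 1, `CCOC(=O)C1=Cc2ccccc2OC1(OCc1cn(-c2ccccc2)nn1)C(F)(F)F`, reports only a limit in a functional assay on MCF7 cells (Homo sapiens) for inhibition, read by MTT assay, with a stated time of 24 h; a lower number here means a stronger inhibitor, a higher number a weaker inhibitor: > 150000 nM.
Compound 2, `COc1ccc(-c2cc(COC3(C(F)(F)F)Oc4ccccc4C=C3C(=O)O)on2)cc1`, gives 35200 nM in this assay.
Compound 3, `CCOC(=O)C1=Cc2ccccc2OC1(OCc1cc(-c2cccc(C(F)(F)F)c2)no1)C(F)(F)F`, gives 22100 nM.

Compound 1 stands at the limit of > 150000 nM in this assay, at which 1 of the 3 values shown sits, so no number is known for it. Compounds 2 and 3 give numbers, and the gap between them lies within the usual scatter. Compound 4, `CCOC(=O)C1=Cc2ccccc2OC1(OCc1cn(-c2ccc([N+](=O)[O-])cc2)nn1)C(F)(F)F`, differs from compound 1 in one place: nitro in place of hydrogen on an aromatic carbon. Among the measured compounds shown here, no measured pair shows this change, so its effect in this assay is unknown; a small to modest step toward a stronger inhibitor is expected, with a real chance that compound 4 also stays at the limit. The expected value for compound 4 is 80000 nM, between 25000 nM and 250000 nM. The estimated step is an at least 1.8-fold lower number from compound 1 to compound 4 (0.27 log units; that floor lies within the scatter).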

Compound 4, half-maximal inhibitory concentration: > 150000 nM
Compound 4: no number, only a limit; the forecaster's own chance of this, stated with the estimate: 45%; at least 1.8-fold (0.27 log units) between middle value and limit.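

Compound 1 and compound 4 each give only a limit in this assay, not a number, so no step can be read between them. As far as these compounds go, whether going from phenyl to 4-nitrophenyl changes inhibition at all, and in which direction, stays open.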